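Chain length and linker change on a selenocyanate series

The compounds below may be only part of what the source reports. "The series", "measured", "known", "first", "only" and "open" are said of these compounds alone.

Measured compounds:
Compound 1 `COc1ccc(N(C)c2nc(C)nc3ccccc23)cc1C(=O)OCCC[Se]C#N`: 1180 nM
Compound 2 `COc1ccc(N(C)c2nc(C)nc3ccccc23)cc1C(=O)OCCCCC[Se]C#N`: 851 nM
Compound 3 `C[Se]c1ccc(N(C)c2nc(C3CC3)nc3ccccc23)cc1`: 18 nM

In a functional assay on MDA-MB-231 cells (Homo sapiens) for inhibition, read by MTT assay, with a stated time of 48 h (on this read-out higher numbers stand for weaker inhibition and lower numbers for stronger inhibition), compound 1 gives the highest number of the three, so it is the weakest inhibitor shown. Compound 2 lies close to it, and the step of a 1.4-fold lower number from compound 1 to compound 2 (0.14 log units; within the scatter) is within the scatter. For the measured compounds named here, compound 3, which carries a different group on the shared core, gives a far lower number, but no single-place step links it to compound 1.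

The unmeasured compound 4 `COc1ccc(N(C)c2nc(C)nc3ccccc23)cc1OCCCCCC[Se]C#N` differs from compound 1 as follows: a group of 10 heavy atoms (7 carbon, 1 nitrogen, 1 oxygen, 1 selenium; no ring) in place of a group of 9 heavy atoms (5 carbon, 1 nitrogen, 2 oxygen, 1 selenium; no ring), on an aromatic carbon. The change keeps the selenium-bearing chain but swaps the group with a double bond outside aromatic rings for a longer one without it, placed ortho to a methoxy group and meta to a large group.

Going by the values given here, the only measured step that bears on this is the one from compound 1 to compound 2, where a longer chain moved the number within the scatter. Among the compounds with values here, a change of linker has no measured counterpart here. The expectation is therefore a step of about a 1.5-fold lower number from compound 1 to compound 4 (0.17 log units; within the scatter) in this assay, most likely within the scatter, with a slight lean toward a lower number. Compound 4 is estimated at 800 nM, with a range from 300 nM to 2500 nM.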

Compound 4, half-maximal inhibitory concentration: 3550 nM
Compound 4: middle estimate off by 4.4-fold (0.65 log units), on the low side; the measured number lies above the stated range.
By their numbers in this assay, from the lowest: compound 3; then compounds 2 and 1 (each within the scatter of the next); then compound 4.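

In this assay, this aromatic carbon proves sensitive to what is attached there: replacing the group of 9 heavy atoms, which holds a double bond outside the aromatic rings, with the longer group of 10 heavy atoms that lacks one gives a 3.0-fold higher number from compound 1 to compound 4 (0.48 log units; beyond the scatter). The step is beyond the scatter and in the direction of weaker inhibition, whereas lengthening the chain while keeping the carbonyl gave only a 1.4-fold lower number from compound 1 to compound 2 (0.14 log units; within the scatter), which is within the scatter. Nothing available here explains why the number rises with this change.

The new step changes the link to the ring and the size of the group together, so the compounds shown cannot separate the effect of losing the carbonyl from the effect of the different chain. An amide link carrying the same selenocyanate chain, or a shorter chain on the oxygen of compound 4, would be the kind of neighbour needed to show which part of the change accompanies the higher number.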